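The source may report more compounds than this note shows. Statements on the series, on what has been measured and on what is new or still open speak of the compounds shown alone.

Compound 1 `O=[N+]([O-])c1ccc(S(=O)(=O)Nc2cccc3cc[nH]c23)cc1` gives 7.2 ug/mL in a functional assay on MC-38 cells (Mus musculus) for antiproliferative activity, read by colorimetric assay and MTT assay; on this read-out lower numbers stand for stronger inhibition and higher numbers for weaker inhibition. Compound 2 `O=[N+]([O-])c1ccc(S(=O)(=O)Nc2cc(Cl)cc3cc[nH]c23)cc1` differs from it by chloro in place of hydrogen on an aromatic carbon, and compound 2 gives 13 ug/mL, so that a 1.8-fold higher number from compound 1 to compound 2 (0.26 log units; within the scatter). Compound 3 `Nc1ccc(S(=O)(=O)Nc2cccc3cc[nH]c23)cc1` carries the other core; it differs from compound 1 by amino in place of nitro on an aromatic carbon, and compound 3 gives 6.1 ug/mL, so that a 1.2-fold lower number from compound 1 to compound 3 (0.07 log units; within the scatter). Compound 4 `Nc1ccc(S(=O)(=O)Nc2cccc3c(Cl)c[nH]c23)cc1` is not yet measured and differs from compound 3 by chloro in place of hydrogen on an aromatic carbon. This is the same kind of change as from compound 1 to compound 2, but not the same: here the chloro enters on an aromatic carbon of a five-membered aromatic ring with 1 nitrogen, two ring bonds from the ring nitrogen, whereas in compound 2 it enters on a six-membered aromatic ring of carbon only, meta to a fused ring, meta to a large group and para to a fused ring. A step of a 1.6-fold higher number from compound 3 to compound 4 (0.19 log units; within the scatter) is expected. That expectation rests on the step of a 1.8-fold higher number from compound 1 to compound 2 (0.26 log units; within the scatter) and on compound 3 giving 6.1 ug/mL. Compound 4 is estimated at 9.5 ug/mL, between 4.5 ug/mL and 20 ug/mL.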

Compound 4, half-maximal inhibitory concentration: 0.23 ug/mL
For compound 4 the middle estimate is 41-fold (1.62 log units) above the measured one; the whole stated range lies above it.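

In this assay chloro in place of hydrogen gives a 27-fold lower number from compound 3 to compound 4 (1.42 log units; beyond the scatter) when it enters on an aromatic carbon of the five-membered aromatic ring, so this change does not carry from one core to another in this series as a single fixed step: the same change on two cores in this assay, a 1.8-fold higher number (0.26 log units; within the scatter) from compound 1 to compound 2 and a 27-fold lower number (1.42 log units; beyond the scatter) from compound 3 to compound 4, 48-fold (1.68 log units) apart, beyond the scatter of two such steps. The two steps differ in two things at once, since the chloro sits on a different ring and the other core carries amino in place of nitro. They therefore do not show which of these two differences separates the steps. The compounds shown leave open whether chloro on that same carbon would give a similar step with nitro in place of amino, and whether bromo or methyl there would match chloro.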